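Adding a Benzyl Ester Group at the Glycine Carbon

This account rests on a few compounds, and the source may have more. Where it says the series, first, only, none or still open, it means among the compounds named here.

In a functional assay on the whole organism (Tail, strain ICR) with Mus musculus as the target, in the tail flick test, with a stated time of 120 min, at a dose of 25 umol/kg by the oral route (on this read-out lower numbers stand for a weaker effect and higher numbers for a stronger effect at the one dose given), compound 3 `O=C(CN(c1ncnc2c1ncn2C1CCCCO1)C1CC1)NCC(=O)OCc1ccccc1` gives 17.2%. Compound 1 `CC[C@H](C)[C@H](NC(=O)CN(c1ncnc2c1ncn2C1CCCCO1)C1CC1)C(=O)OCc1ccccc1` gives 20.4%, and compound 2 `C[C@H](NC(=O)CN(c1ncnc2c1ncn2C1CCCCO1)C1CC1)C(=O)OCc1ccccc1` gives 25.3%. The steps of a number 3.2 percentage points lower from compound 1 to compound 3 (within the scatter) and a number 8.1 percentage points lower from compound 2 to compound 3 (within the scatter) both lie within the scatter, so the three numbers cannot be told apart. Compound 4 `O=C(CN(c1ncnc2c1ncn2C1CCCCO1)C1CC1)N[C@@H](CC(=O)OCc1ccccc1)C(=O)OCc1ccccc1` differs from compound 3 by (benzyloxycarbonyl)methyl in place of hydrogen on a saturated chain carbon bound to an amide-type nitrogen and a carbonyl carbon. The two measured steps that bear on this change sit at the same place, and both stayed within the scatter when sec-butyl or methyl replaced hydrogen there. Within the data shown here, no measured step tells what (benzyloxycarbonyl)methyl does at this place, so a step of a number 2.8 percentage points higher from compound 3 to compound 4 (within the scatter) is expected, none beyond the scatter. Compound 4 is therefore estimated at 20%, in the range 8% to 32%.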

Compound 4, a percentage reported as activity, at one dose (the size of the read-out at that dose, not a potency): 7.82%
The estimate for compound 4 lay 12.2 percentage points above the measured number, and the stated range ends above it.
By their numbers in this assay, from the lowest: compounds 4, 3, 1 and 2 (each within the scatter of the next, the first and the last beyond it).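

In this assay this place gives its first steps beyond the scatter, with a number 17.5 percentage points lower from compound 2 to compound 4 (beyond the scatter) and a number 12.6 percentage points lower from compound 1 to compound 4 (beyond the scatter) once (benzyloxycarbonyl)methyl enters. Set against hydrogen, the same group gives a number 9.4 percentage points lower from compound 3 to compound 4 (within the scatter) so it stands apart from methyl and sec-butyl but not from hydrogen. Nothing measured here explains these steps. The compounds shown leave open what a carboxylic acid or an amine would give on this saturated chain carbon. As far as these compounds go, whether a longer chain carrying the benzyl ester would behave like (benzyloxycarbonyl)methyl also stays open.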